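Bromo to Amino on a Shared Core Near the Assay Limit

The source may hold more compounds than are shown below. What is called first, only, known or untested is meant among the compounds shown, and "the series" means these compounds.

Compound 1 `Fc1cccc(-c2nc(Nc3ccccc3F)c3cc(F)ccc3n2)c1` was tested in a functional assay on HT29-AK cells (Homo sapiens) for cytotoxicity, read by MTT assay, with a stated time of 48 h; on this read-out lower numbers stand for stronger inhibition and higher numbers for weaker inhibition. In this assay compound 1 gives > 50000 nM, a limit of the assay rather than a number. Compound 2 `Fc1cccc(-c2nc(Nc3ccccc3Br)c3cc(F)ccc3n2)c1` differs from it by a step that the two limits leave unreadable from compound 1 to compound 2. In this assay compound 2 gives > 50000 nM, likewise a limit. Both values sit at the limit of > 50000 nM in this assay, at which 2 of the 2 values shown sit, so their step cannot be read. Compound 3 `Nc1ccccc1Nc1nc(-c2cccc(F)c2)nc2ccc(F)cc12` carries amino in place of bromo on an aromatic carbon. Among the measured compounds shown here, no measured step speaks to this change in either direction. Compound 3 is therefore expected near 50000 nM, between 15000 nM and 150000 nM, most likely again as a limit. The expected step is a number no higher from compound 2 to compound 3 (the limit leaves the size open).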

Compound 3, half-maximal inhibitory concentration: > 50000 nM
Compound 3: a limit, no number (the forecaster's own chance of this, stated with the estimate: 75%); the middle value lies on the limit itself.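

In this assay, among the compounds shown here, compound 3 also gives a limit, so no step among compound 1, compound 2 and compound 3 can be read: the limit of > 50000 nM in this assay, at which 3 of the 3 values shown sit. Going by these compounds, whether fluoro, bromo or amino at this place makes any difference to cytotoxicity stays open.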